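Trifluoromethyl removal at two different places in the series

The compounds below may be only part of what the source reports. "The series", "measured", "known", "first", "only" and "open" are said of these compounds alone.

Compound 2 `O=C(Nc1ccc(C(F)(F)F)cc1)c1csc(Cc2c(Cl)cccc2Cl)n1` gives, in an assay on CHO cells, read by calcium flux (on this read-out lower numbers stand for stronger inhibition and higher numbers for weaker inhibition), a value of 140 nM. Compound 1 `O=C(Nc1ccccc1)c1csc(Cc2c(Cl)cccc2Cl)n1` differs from it by hydrogen in place of trifluoromethyl on an aromatic carbon. In this assay compound 1 gives only a limit, > 4000 nM. The measured step is an at least 28-fold higher number from compound 2 to compound 1 (1.45 log units; beyond the scatter). Compound 3 `O=C(Nc1ccc(C(F)(F)F)cc1)c1csc(Nc2c(Cl)cccc2C(F)(F)F)n1` keeps the amide part of compound 2, but the difference between the two cores is not broken down here. In this assay compound 3 gives only a limit, > 4000 nM. Compound 4 `O=C(Nc1ccc(C(F)(F)F)cc1)c1csc(Nc2ccccc2Cl)n1`, still to be measured, differs from compound 3 by hydrogen in place of trifluoromethyl on an aromatic carbon. This is the same kind of change as from compound 2 to compound 1, not the same: there the place was para to a large group, here it is ortho to a large group and meta to a chloro group. Compound 3 already stands at the limit of > 4000 nM in this assay, at which 2 of the 3 values shown sit, so no loss can be read from there. The step to compound 4 is expected to be a step that the limit leaves unreadable from compound 3 to compound 4, resting on the absence of any measured change at this place. Compound 4 is expected to give about 5000 nM, between 600 nM and 30000 nM.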

Compound 4, half-maximal inhibitory concentration: 1750 nM
Compound 4: the middle estimate sits 2.9-fold (0.46 log units) above what was measured; the range from low to high includes it.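

Hydrogen in place of trifluoromethyl does not carry over between these two cores in this assay, where the steps run in opposite directions: the same change on two cores in this assay, an at least 28-fold higher number (1.45 log units; beyond the scatter) from compound 2 to compound 1 and an at least 2.2-fold lower number (0.35 log units; beyond the scatter) from compound 3 to compound 4, at least 65-fold (1.81 log units) apart, beyond the scatter of two such steps

The new step, an at least 2.2-fold lower number from compound 3 to compound 4 (0.35 log units; beyond the scatter), gives only a minimum size, and compound 3 stands at a limit of the assay, not at a number: the limit of > 4000 nM in this assay, at which 2 of the 4 values shown sit.

Compound 4 also stays short of compound 2, with a 13-fold higher number from compound 2 to compound 4 (1.10 log units; beyond the scatter), and since the two changes sit at different places on different cores, the data do not show whether core or place separates them.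

Open, as far as these compounds go, is whether the amide-side trifluoromethyl matters on the core of compound 4. Also open, from the compounds shown here alone, is how a methoxy group or a nitrile would read at the place where compound 4 carries hydrogen.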